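Quinoline acid series: cyclohexyl amide, keratinocyte inhibition

A few compounds are considered here, and "the series" means these few. Any claim that something is new, unique, unknown or untested is made for them only; others in the source may bear on it.

Measured so far:
compound 1 `COc1cc(-c2cc(C(=O)O)c3ccccc3n2)ccc1OCC(=O)Nc1cccc(C)c1` — 225000 nM
compound 2 `COc1cc(-c2cc(C(=O)O)c3ccccc3n2)ccc1OCC(=O)Nc1ccccc1F` — 161000 nM
compound 3 `COc1cc(-c2cc(C(=O)O)c3ccccc3n2)ccc1OCC(=O)Nc1ccccc1Cl` — 210000 nM

All three were run in an ADME assay on HaCaT cells (Homo sapiens) for inhibition; a higher number here means a weaker inhibitor, a lower number a stronger inhibitor. Compound 3 holds the second highest of the three numbers; its nearest neighbour is compound 1 and its furthest is compound 2, and both gaps are within the scatter, so the three stand together.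

Compound 4 `COc1cc(-c2cc(C(=O)O)c3ccccc3n2)ccc1OCC(=O)NC1CCCCC1` is not yet measured. It differs from compound 3 in one place: cyclohexyl in place of 2-chlorophenyl on an amide-type nitrogen.

The measured steps all exchange one six-membered aromatic ring on the amide-type nitrogen for another: a 1.4-fold lower number from compound 1 to compound 2 (0.15 log units; within the scatter), a 1.1-fold lower number from compound 1 to compound 3 (0.03 log units; within the scatter), a 1.3-fold higher number from compound 2 to compound 3 (0.12 log units; within the scatter). Among the compounds with values here, none of them moves the number beyond the scatter, and none replaces the aromatic ring with a non-aromatic one, so no measured step speaks directly to the move to cyclohexyl. With every change on this nitrogen so far leaving this assay flat, compound 4 is expected to stay near compound 3, the expected step being a 1.1-fold lower number from compound 3 to compound 4 (0.02 log units; within the scatter), with a wider range than usual to cover the untested kind of change. Compound 4 is therefore estimated at 200000 nM, between 90000 nM and 450000 nM.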

Compound 4, half-maximal inhibitory concentration: > 300000 nM
Compound 4 was reported as a limit; the forecaster's own chance of this, stated with the estimate: 20%; at least 1.5-fold (0.17 log units) between middle value and limit.
By their numbers in this assay, from the lowest: compounds 2, 3 and 1 (each within the scatter of the next). At a limit, above all of these: compound 4.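

In this assay compound 4 gives > 300000 nM, which is a limit of the assay and not a number. Putting a non-aromatic ring on the amide-type nitrogen gives an at least 1.4-fold higher number from compound 3 to compound 4 (0.15 log units; that floor lies within the scatter), an at least 1.8-fold higher number from compound 2 to compound 4 (0.27 log units; that floor lies within the scatter) and an at least 1.3-fold higher number from compound 1 to compound 4 (0.12 log units; that floor lies within the scatter); unlike the exchanges among aromatic rings, this change has a direction against all three aromatic amides, towards a higher number, although each floor stays within the scatter. The true size of the step therefore cannot be read, and a change beyond the scatter is neither shown nor excluded, with the reading for compound 4 capped as follows: the limit of > 300000 nM in this assay, at which 1 of the 4 values shown sits.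

The compounds shown leave open whether the ring's non-aromatic character matters in itself or whether any other group on this nitrogen would separate from the aromatic amides, for example a straight hexyl chain, a cyclopentyl ring or a phenyl ring carrying an amine. They also leave open how far the flat behaviour extends beyond this nitrogen, for example with a methyl ester in place of the carboxylic acid on the shared core.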